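Halogen Swap on a Five-Membered Ring: Chloro to Bromo

The compounds below may be only part of what the source reports. "The series", "measured", "known", "first", "only" and "open" are said of these compounds alone.

Compound 1, `CCCCC/C=C\C[C@]1(O)C=CC(=O)/C1=C/C=C\CCCC(=O)OC`: 7200 nM
Compound 2, `CCCCC/C=C\C[C@@]1(O)C=C(Cl)C(=O)/C1=C/C=C/CCCC(=O)OC`: 1900 nM

Both compounds were tested in a functional assay on PC-3 cells (Homo sapiens) for cytotoxicity, read by sulforhodamine B assay, with a stated time of 72 h; a lower number here means a stronger inhibitor, a higher number a weaker inhibitor. Compound 2 gives 1900 nM, the lower of the two numbers. Compound 1 gives 7200 nM, and the gap between the two lies beyond the usual scatter. Within the data shown here, since the two structures differ in more than one place, this gap cannot be tied to any single change, and no step between measured compounds is available here.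

Compound 3, `CCCCC/C=C\C[C@@]1(O)C=C(Br)C(=O)/C1=C/C=C/CCCC(=O)OC`, has not yet been measured in this assay. It differs from compound 2 in one place: bromo in place of chloro on a double-bonded ring carbon. Among the measured compounds shown here, nothing among the measured compounds shows what such an exchange does in this assay, so the expectation rests on the small size of the change alone. The step of a 1.3-fold lower number from compound 2 to compound 3 (0.10 log units; within the scatter) is expected to be small, at most a modest shift toward a lower number, and it may well fall within the scatter. Compound 3 is therefore estimated at 1500 nM, with a likely range from 600 nM to 4000 nM.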

Compound 3, half-maximal inhibitory concentration: 5600 nM
The estimate for compound 3 lay 3.7-fold (0.57 log units) below the measured number, and the stated range ends below it.
By their numbers in this assay, from the lowest: compound 2; then compounds 3 and 1 (each within the scatter of the next).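

In this assay the exchange of chloro for bromo on a double-bonded ring carbon is the first single change that can be read among these compounds, and it is not neutral: the number rises, with a 2.9-fold higher number from compound 2 to compound 3 (0.47 log units; beyond the scatter) as the step. This position, two ring bonds from the ring atom that bears a hydroxy group and two ring bonds from the ring atom that bears an oct-2-en-1-yl group, therefore distinguishes between the two halogens, even though one heavy atom replaces one heavy atom and no hydrogen-bond donor or acceptor is gained or lost. No measurement shown here accounts for this step, which stands as an observation on this one pair.

From the compounds shown here alone, whether fluoro, iodo, a methyl group or a nitrile on this carbon would give a lower or a higher number in this assay remains open. Compound 1 carries hydrogen on this carbon but differs from compound 2 in more than one place, so what chloro itself contributes cannot be read from the compounds shown.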